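From 4-Fluorophenyl to 2-Chlorophenyl: Compound 4

A few compounds are considered here, and "the series" means these few. Any claim that something is new, unique, unknown or untested is made for them only; others in the source may bear on it.

Three measured compounds share one core and differ only in the aromatic group attached to an amine nitrogen in a ring. Compound 1 `CC(C(=O)N1CCN(c2ccccc2)CC1)N1C(=O)CCC1=O` gives 100% in a functional assay on the whole organism (strain Swiss) with Mus musculus as the target, in the maximal electroshock model, with a stated time of 0.25 h, at a dose of 300 mg/kg by the intraperitoneal route; a higher number here means a stronger effect of the compound at the dose given, a lower number a weaker effect. Compound 2 `CC(C(=O)N1CCN(c2ccc(Cl)cc2)CC1)N1C(=O)CCC1=O` gives 100% in this assay, and compound 3 `CC(C(=O)N1CCN(c2ccc(F)cc2)CC1)N1C(=O)CCC1=O` gives 100% in this assay. The steps among them are no change at the digits printed from compound 1 to compound 2 (within the scatter), no change at the digits printed from compound 1 to compound 3 (within the scatter) and no change at the digits printed from compound 2 to compound 3 (within the scatter). Compound 3 therefore stands level with compounds 1 and 2 on these numbers, compound 1 being its nearest neighbour and compound 2 its furthest, neither separated from it beyond the scatter.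

Compound 4 `CC(C(=O)N1CCN(c2ccccc2Cl)CC1)N1C(=O)CCC1=O` has not yet been measured. Its change from compound 3 is 2-chlorophenyl in place of 4-fluorophenyl on an amine nitrogen in a ring. Going by the values given here, the steps that bear on this are those in which a halogen was added to the aromatic ring or one halogen exchanged for another, no change at the digits printed from compound 1 to compound 3 (within the scatter), no change at the digits printed from compound 1 to compound 2 (within the scatter) and no change at the digits printed from compound 2 to compound 3 (within the scatter); none of them moved the read-out. Among the compounds with values here, no measured compound carries a 2-chlorophenyl group, so no direct step for that exact group exists among the data. Even so, the read-out is expected to remain where the three measured compounds stand, and the expected step is no change at the digits printed from compound 3 to compound 4 (within the scatter). Compound 4 is accordingly estimated at 100%, with a range from 80% to 100%.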

Compound 4, a percentage reported as activity, at one dose (the size of the read-out at that dose, not a potency): 0%
Compound 4: the middle estimate sits 100 percentage points above what was measured; the measured number lies below the stated range.
By their numbers in this assay, from the lowest: compound 4; then compounds 1, 2 and 3 (each within the scatter of the next).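

Going by these compounds alone, the flat picture among the earlier compounds does not hold for every placement of a halogen on the aromatic group on an amine nitrogen in a ring: in this assay, putting chloro in place of hydrogen to give the 2-chlorophenyl group brings a number 100 percentage points lower from compound 1 to compound 4 (beyond the scatter), whereas the same kind of change gave no shift in compound 2. The sharpest comparison is a number 100 percentage points lower from compound 2 to compound 4 (beyond the scatter), a step in which the same halogen stays on the ring and only its place changes, from the 4-chlorophenyl group to the 2-chlorophenyl group, so the place of the chloro substituent decides the outcome in this pair. Within the data shown here, the exchange of 4-fluorophenyl for 2-chlorophenyl gives the same result, a number 100 percentage points lower from compound 3 to compound 4 (beyond the scatter), which shows that this part of the molecule is not indifferent to substitution, as the earlier compounds alone had suggested.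

The compounds shown leave open whether the loss belongs to chlorine alone or would also follow with 2-fluorophenyl, 2-methylphenyl or 2-methoxyphenyl, and how 3-chlorophenyl would behave. No evidence here bears on why the read-out falls away with this change.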